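Substituent change on the cinnamoyl ring: hydrogen to methoxy

The source may report more compounds than this note shows. Statements on the series, on what has been measured and on what is new or still open speak of the compounds shown alone.

Within the data shown here, compound 2 `O=C(/C=C/c1ccccc1)Nc1cc(-c2ccc(Br)cc2)[nH]n1` is one of two compounds measured in a functional assay on A549 cells (Homo sapiens) for antiproliferative activity, read by MTT assay, with a stated time of 48 h; on this read-out higher numbers stand for weaker inhibition and lower numbers for stronger inhibition; in that assay compound 2 gives 1440 nM, the higher of the two numbers. Among the measured compounds shown here, its only measured neighbour is compound 1 `O=C(/C=C/c1ccc(Cl)cc1)Nc1cc(-c2ccc(Br)cc2)[nH]n1`, which in this assay gives 1210 nM. For the measured compounds named here, the single step between them, a 1.2-fold higher number from compound 1 to compound 2 (0.08 log units; within the scatter), is hydrogen in place of chloro on an aromatic carbon and lies within the scatter, so the two values cannot be told apart.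

Compound 3 `COc1ccc(/C=C/C(=O)Nc2cc(-c3ccc(Br)cc3)[nH]n2)cc1` has not yet been measured. It differs from compound 2 by methoxy in place of hydrogen on an aromatic carbon. Going by the values given here, no step involving a methoxy group is available, so the only bearing evidence is the step from compound 1 to compound 2, which shows that a change at the same aromatic carbon left the number essentially unchanged. The expectation is therefore a step, a 1.1-fold lower number from compound 2 to compound 3 (0.04 log units; within the scatter), that stays within the scatter in either direction.

Compound 3 is accordingly expected to give about 1300 nM in this assay, with a likely range of 600 nM to 3000 nM.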

Compound 3, half-maximal inhibitory concentration: 820 nM
Estimate against measurement, compound 3: 1.6-fold (0.20 log units) above, within the range that was stated.
By their numbers in this assay, from the lowest: compounds 3, 1 and 2 (each within the scatter of the next).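

In this assay, putting methoxy on this aromatic carbon, para to a large group, gives a 1.8-fold lower number from compound 2 to compound 3 (0.24 log units; within the scatter), and exchanging chloro for methoxy at the same carbon gives a 1.5-fold lower number from compound 1 to compound 3 (0.17 log units; within the scatter), so methoxy cannot be told apart from either hydrogen or chloro here. Among these compounds, the earlier pair showed this only for chloro and hydrogen; the same carbon has now carried three different substituents, one of them with 2 heavy atoms and 1 hydrogen-bond acceptor, and no step among the three compounds leaves the scatter, so none of these changes can be said to alter the antiproliferative read-out. Nothing available on these compounds offers an explanation for their values.

The compounds shown leave open whether a group of another kind at this carbon, such as an amine, a carboxylic acid or a longer chain like butoxy, would produce a step beyond the scatter. They also leave open whether methoxy would behave in the same way on another carbon of this ring, and how much the bromine-bearing part of the shared core contributes to the values.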